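Ester series: plasma half-life, cyclopropyl to 3-acetamidophenyl

The compounds below may be only part of what the source reports. "The series", "measured", "known", "first", "only" and "open" are said of these compounds alone.

Compound 1 `CC(=O)Oc1ccccc1C(=O)O[C@H]1CO[C@H]2[C@@H]1OC[C@H]2OC(=O)C1CC1` and compound 2 `CC(=O)Oc1ccccc1C(=O)O[C@H]1CO[C@H]2[C@@H]1OC[C@H]2OC(=O)c1ccc(C)cc1` share a core and differ only in the group on one carbonyl carbon; both have been run in an ADME assay on a cell-free system (plasma, Homo sapiens) for metabolic stability, with Plasma (Rattus norvegicus) as the target, read by HPLC, at pH 7.4; on this read-out lower numbers stand for a shorter-lived compound and higher numbers for a longer-lived compound. Among the compounds with values here, compound 1 gives 0.015 h, the lowest of the two numbers so far. Compound 2 gives 0.0362 h. Within the data shown here, the single measured step is a 2.4-fold higher number from compound 1 to compound 2 (0.38 log units; beyond the scatter), with 4-methylphenyl in place of cyclopropyl on the carbonyl carbon.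

Compound 3 `CC(=O)Nc1cccc(C(=O)O[C@@H]2CO[C@H]3[C@@H]2OC[C@@H]3OC(=O)c2ccccc2OC(C)=O)c1` is not yet measured. Against compound 1 the change is 3-acetamidophenyl in place of cyclopropyl on a carbonyl carbon. Among the measured compounds shown here, the only step that bears on it is the one between compound 1 and compound 2, where a six-membered aromatic ring of carbon only also entered in place of cyclopropyl at the same carbonyl carbon and the number rose modestly. A step of similar size and the same direction is therefore expected, namely a 2.3-fold higher number from compound 1 to compound 3 (0.37 log units; beyond the scatter). Compound 3 is expected at 0.035 h, with a range from 0.015 h to 0.08 h.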

Compound 3, half-life: 0.0583 h
The estimate for compound 3 lay 1.7-fold (0.22 log units) below the measured number, within the range that was stated.
By their numbers in this assay, from the lowest: compound 1; then compounds 2 and 3 (each within the scatter of the next).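

In this assay a second six-membered aromatic ring of carbon only in place of cyclopropyl on the carbonyl carbon also gives a higher number (a 3.9-fold higher number from compound 1 to compound 3 (0.59 log units; beyond the scatter)), and neither compound shown with such a ring goes against this rise. Compounds 2 and 3 cannot be separated (a 1.6-fold higher number from compound 2 to compound 3 (0.21 log units; within the scatter)), so 3-acetamidophenyl and 4-methylphenyl read alike at this position, although they differ in heavy atoms and hydrogen-bond donors and acceptors. Nothing at hand accounts for the rise over cyclopropyl.

Going by these compounds, whether the rise goes with the aromatic ring or with the size of the group remains open, and a cyclohexyl group or a longer alkyl chain on the same carbonyl carbon would bear on this. Also open, on these data alone, is whether an amine or a carboxylic acid on the phenyl ring would keep compound 2 and compound 3 level.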